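Ring Size at the Chain End in a Quinazoline Set

The compounds below may be only part of what the source reports. "The series", "measured", "known", "first", "only" and "open" are said of these compounds alone.

Measured compounds:
compound 1, `COc1cc2c(Nc3ccc(C#N)cc3)ncnc2cc1OCCCN1CCCC1`: 21800 nM
compound 2, `COc1cc2c(Nc3ccc(C#N)cc3)ncnc2cc1OCCCN1CCCCC1`: 23500 nM
compound 3, `COc1cc2c(Nc3ccccc3C#N)ncnc2cc1OCCCN1CCCC1`: 21800 nM

In a functional assay on A549 cells (Homo sapiens) for antiproliferative activity, read by MTT assay, with a stated time of 72 h (on this read-out lower numbers stand for stronger inhibition and higher numbers for weaker inhibition), compound 1 gives 21800 nM and compound 2 gives 23500 nM. The two differ by one change, (piperidin-1-yl in place of pyrrolidin-1-yl on a saturated chain carbon, three bonds along the chain from an oxygen on an aromatic ring), and the step it made is a 1.1-fold higher number from compound 1 to compound 2 (0.03 log units; within the scatter). Compound 3 gives 21800 nM in this assay; it differs from compound 1 by 2-cyanophenyl in place of 4-cyanophenyl on a nitrogen on an aromatic ring, and that step is no change at the digits printed from compound 1 to compound 3 (within the scatter). All three numbers therefore sit close together, and none of the three compounds can be called stronger or weaker than another.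

Compound 4, `COc1cc2c(Nc3ccccc3C#N)ncnc2cc1OCCCN1CCCCC1`, has not yet been measured. It differs from compound 3 by piperidin-1-yl in place of pyrrolidin-1-yl on a saturated chain carbon, three bonds along the chain from an oxygen on an aromatic ring. Within the data shown here, this is the same change, at the same place, as the one that separates compound 2 from compound 1. The cores of compound 3 and compound 4 differ from those of compound 1 and compound 2 in the way described above for compound 1 and compound 3.

The step from compound 3 to compound 4 in this assay is expected to be about as small as the earlier one, a 1.1-fold higher number from compound 3 to compound 4 (0.02 log units; within the scatter), because the same change gave a 1.1-fold higher number from compound 1 to compound 2 (0.03 log units; within the scatter) and the core change itself gave no change at the digits printed from compound 1 to compound 3 (within the scatter). On that basis compound 4 is estimated at 23000 nM, with a likely range from 12000 nM to 45000 nM.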

Compound 4, half-maximal inhibitory concentration: 14700 nM
Estimate against measurement, compound 4: 1.6-fold (0.19 log units) above; the range from low to high includes it.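

In this assay, putting piperidin-1-yl in place of pyrrolidin-1-yl gives a 1.5-fold lower number from compound 3 to compound 4 (0.17 log units; within the scatter), and this step does not differ beyond the scatter from the same change on the core of compound 1: the same change on two cores in this assay, a 1.1-fold higher number (0.03 log units; within the scatter) from compound 1 to compound 2 and a 1.5-fold lower number (0.17 log units; within the scatter) from compound 3 to compound 4, 1.6-fold (0.20 log units) apart, within the scatter of two such steps

Read the other way round, 2-cyanophenyl in place of 4-cyanophenyl gives a 1.6-fold lower number from compound 2 to compound 4 (0.20 log units; within the scatter), and this step also agrees with its earlier reading: the same change on two cores in this assay, no change at the digits printed (within the scatter) from compound 1 to compound 3 and a 1.6-fold lower number (0.20 log units; within the scatter) from compound 2 to compound 4, 1.6-fold (0.20 log units) apart, within the scatter of two such steps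

For these four compounds, then, each change reads the same on both cores within the scatter, but every step is itself within the scatter, so the agreement is only between steps too small to tell from repeat noise; it does not show that either change alters the antiproliferative effect, nor that a change with a clear effect would carry from one core to another in the same way.

Still open, going by these compounds, is whether a different amine at the chain end, such as morpholin-4-yl or dimethylamino, or a longer chain than 3-(piperidin-1-yl)propyl, would move the number beyond the scatter. The same question applies on the aromatic ring, where 3-cyanophenyl or a chlorophenyl group in place of the cyanophenyl groups would test whether any such step could be carried between cores.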